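This account rests on a few compounds, and the source may have more. Where it says the series, first, only, none or still open, it means among the compounds named here.

Compound 1, `Cc1cccc(CSc2nc3cc(NC(=O)C4CC4)ccc3n2C(C)C)c1`: > 10000 nM in an assay on isolated protein for inhibition of Gonadotropin-releasing hormone receptor (Rattus norvegicus); on this read-out lower numbers stand for stronger inhibition and higher numbers for weaker inhibition.
Compound 2, `COc1ccc(C(C)=O)cc1CSc1nc2cc(NC(=O)C3CC3)ccc2n1C(C)C`: > 10000 nM in this assay.
Compound 3, `CCCCn1c(SCc2cc([N+](=O)[O-])ccc2OC)nc2cc(NC(=O)NC(C)(C)C)ccc21`: 330 nM in this assay.

The value for compound 1 is a limit of this assay and not a number. The value for compound 2 is likewise a limit, not a number. Within the data shown here, compound 3 thus stands alone as the only compound with an actual number in this assay; the other two sit at the limit of > 10000 nM in this assay, at which 2 of the 3 values shown sit. The three compounds differ in more than one place. Among the measured compounds shown here, no single step between them can be read.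

Compound 4, `COc1ccc([N+](=O)[O-])cc1CSc1nc2cc(NC(=O)NC(C)(C)C)ccc2n1C(C)C`, is built from compound 3 by one change: isopropyl in place of butyl on an aromatic nitrogen. Nothing else moves. The butyl chain is only one carbon longer than the isopropyl group that replaces it, and both lack donors, acceptors and charge. Compounds 1 and 2 carry the isopropyl group too, but they also differ from compound 3 elsewhere, so their limits say nothing about this step on its own. The expected step from compound 3 to compound 4 is therefore a 1.5-fold higher number from compound 3 to compound 4 (0.18 log units; within the scatter), which lies within the usual scatter. For compound 4 in this assay the estimate is 500 nM, with a range from 150 nM to 3000 nM.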

Compound 4, half-maximal inhibitory concentration: 62 nM
Compound 4: middle estimate off by 8.1-fold (0.91 log units), on the high side; measured number outside the range, below it.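

Among these compounds, this is the first step that can be read at a single place, and it shows that the group on this aromatic nitrogen matters in this assay: with everything else unchanged, isopropyl in place of butyl gives a 5.3-fold lower number from compound 3 to compound 4 (0.73 log units; beyond the scatter). The change is small by count, from 4 carbon to 3 carbon, with no ring, hydrogen-bond donor, hydrogen-bond acceptor or net charge on either side, so even a swap between two such plain groups at this position can move the number beyond the usual scatter. Compounds 1 and 2 also carry isopropyl but differ from compound 4 in more than one place, so no step to them can be read, and each of the two has a limit of the assay and not a number: the limit of > 10000 nM in this assay, at which 2 of the 4 values shown sit.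

A single step cannot separate the loss of one carbon from the change in chain shape, whereas a straight propyl chain or a cyclopropyl group on the same nitrogen could begin to pull the two apart. The compounds shown also leave open why the number drops, and whether butyl and isopropyl would differ in the same way on a core carrying the cyclopropyl amide of compounds 1 and 2.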